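A few compounds are considered here, and "the series" means these few. Any claim that something is new, unique, unknown or untested is made for them only; others in the source may bear on it.

Compound 1, `CC(C)OC(=O)NCCS(=O)(=O)NC(=O)c1ccc(Nc2nc(NC3(c4ccc(Cl)cc4)CC3)nc(OCC(F)(F)F)n2)cc1`: 71 nm/s
Compound 2, `CC(C)S(=O)(=O)NC(=O)c1ccc(Nc2nc(NC3(c4ccc(Cl)cc4)CC3)nc(OCC(F)(F)F)n2)cc1`: 31 nm/s
Compound 3, `O=C(NS(=O)(=O)CCNC(=O)C1CC1)c1ccc(Nc2nc(NC3(c4ccc(Cl)cc4)CC3)nc(OCC(F)(F)F)n2)cc1`: 1 nm/s

These three compounds share one core and differ only in the group attached to the sulfonyl sulfur. In a physicochemical assay for permeability, using PAMPA, at pH 7.4 (on this read-out higher numbers stand for higher permeability and lower numbers for lower permeability), compound 2 holds the second highest of the three numbers: the step of a 2.3-fold lower number from compound 1 to compound 2 (0.36 log units; beyond the scatter) places compound 1 above it, and the step of a 31-fold lower number from compound 2 to compound 3 (1.49 log units; beyond the scatter) places compound 3 far below it. Compound 4, `NCCS(=O)(=O)NC(=O)c1ccc(Nc2nc(NC3(c4ccc(Cl)cc4)CC3)nc(OCC(F)(F)F)n2)cc1`, is not yet measured and differs from compound 2 in one place: 2-aminoethyl in place of isopropyl on a sulfonyl sulfur.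

Among the compounds with values here, two measured steps touch the same position. The step of a 31-fold lower number from compound 2 to compound 3 (1.49 log units; beyond the scatter) shows that exchanging the isopropyl for a longer chain on the sulfonyl sulfur can lower this assay strongly, while the step of a 2.3-fold lower number from compound 1 to compound 2 (0.36 log units; beyond the scatter) shows a modest move the other way between two such chains. The change to compound 4 also replaces the isopropyl with a chain, so a large downward step is expected in this assay, estimated as a 16-fold lower number from compound 2 to compound 4 (1.19 log units; beyond the scatter). For compound 4 the expected value in this assay is 2 nm/s, with a range from 0.5 nm/s to 10 nm/s.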

Compound 4, apparent permeability: 153 nm/s
For compound 4 the middle estimate is 77-fold (1.88 log units) below the measured one, and the stated range ends below it.
By their numbers in this assay, from the lowest: compound 3; then compound 2; then compound 1; then compound 4.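

In this assay, putting a chain on the sulfonyl sulfur does not in itself bring the number down: 2-aminoethyl in place of isopropyl gives a 4.9-fold higher number from compound 2 to compound 4 (0.69 log units; beyond the scatter) and so runs opposite to the drop seen with the 2-((cyclopropylcarbonyl)amino)ethyl chain. Among these compounds, the group on the chain's amine nitrogen sets the outcome, with hydrogen in place of cyclopropylcarbonyl giving a 150-fold higher number from compound 3 to compound 4 (2.18 log units; beyond the scatter) and hydrogen in place of isopropoxycarbonyl giving a 2.2-fold higher number from compound 1 to compound 4 (0.33 log units; beyond the scatter) in the same assay. No measurement shown here accounts for these shifts.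

The compounds shown leave open whether the higher number survives a longer chain, such as 3-aminopropyl, or a dimethylamine at the chain end. A carboxylic acid in place of the amine would show whether the free amine itself matters, or whether other small end groups do equally well.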